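Swapping methoxy for bromo on an aryl enone

A few compounds are considered here, and "the series" means these few. Any claim that something is new, unique, unknown or untested is made for them only; others in the source may bear on it.

Measured so far:
compound 1, `COc1ccc(/C=C/C(=O)c2c(C)[n+]([O-])c3ccccc3[n+]2[O-])cc1`: 93000 nM
compound 2, `Cc1c(C(=O)/C=C/c2ccc(Cl)c(Cl)c2)[n+]([O-])c2ccccc2[n+]1[O-]`: 5700 nM

Going by the values given here, in an ADME assay on HPLF cells (Homo sapiens) for cytotoxicity, with a stated time of 48 h (on this read-out lower numbers stand for higher toxicity in this test and higher numbers for lower toxicity in this test), compound 1 gives 93000 nM, the highest of the two numbers known so far; its nearest neighbour is compound 2, which gives 5700 nM. Among the compounds with values here, the single measured step, a 16-fold lower number from compound 1 to compound 2 (1.21 log units; beyond the scatter), came with 3,4-dichlorophenyl in place of 4-methoxyphenyl on a double-bonded chain carbon bound to a double-bonded chain carbon.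

Compound 3 `Cc1c(C(=O)/C=C/c2ccc(Br)cc2)[n+]([O-])c2ccccc2[n+]1[O-]` has not been measured. It differs from compound 1 by bromo in place of methoxy on an aromatic carbon, on an aromatic carbon of a six-membered aromatic ring of carbon only; cut one bond further out, this reads 4-methoxyphenyl to 4-bromophenyl. Within the data shown here, only the step from compound 1 to compound 2 bears on it: both remove the methoxy and put a halogen on that ring, though compound 3 carries one halogen where compound 2 carries two. Compound 3 is therefore expected to give a lower number in this assay, by a 4.7-fold lower number from compound 1 to compound 3 (0.67 log units; beyond the scatter). Compound 3 is estimated at 20000 nM, between 6000 nM and 60000 nM.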

Compound 3, half-maximal cytotoxic concentration: 26000 nM
Estimate against measurement, compound 3: 1.3-fold (0.11 log units) below, and the stated range covers the measured number.
By their numbers in this assay, from the lowest: compound 2; then compound 3; then compound 1.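

In this assay, a single bromo in place of methoxy is already enough to lower the number beyond the scatter (a 3.6-fold lower number from compound 1 to compound 3 (0.55 log units; beyond the scatter)). The drop seen earlier therefore does not require two halogens on this ring, although one bromo does not reach the level of the 3,4-dichlorophenyl compound (a 4.6-fold higher number from compound 2 to compound 3 (0.66 log units; beyond the scatter)). No measurement shown here explains either step.

As far as these compounds go, whether the gap between the 4-bromophenyl and 3,4-dichlorophenyl compounds follows the number of halogens or the choice of bromine over chlorine stays open, as the two groups differ in both. From the compounds shown here alone, how a 4-chlorophenyl ring, or an amine in place of bromo on the aromatic carbon, would read out in this assay also remains unknown.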